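This account rests on a few compounds, and the source may have more. Where it says the series, first, only, none or still open, it means among the compounds named here.

Measured so far in a physicochemical assay for lipophilicity; on this read-out higher numbers stand for higher lipophilicity and lower numbers for lower lipophilicity:

- compound 1, `COc1ccc(-c2nnc(COc3cnn(C(C)(C)C)c(=O)c3Cl)o2)cc1`: 3.52
- compound 2, `CC(C)(C)n1ncc(OCc2nnc(-c3ccc(Cl)cc3F)o2)c(Cl)c1=O`: 3.23
- compound 3, `CC(C)(C)n1ncc(OCc2nnc(-c3ccc(Br)cc3)o2)c(Cl)c1=O`: 3.21

Compound 3 gives the lowest of the three numbers. Its nearest neighbour is compound 2, which lies within the scatter of it, as the step of a number 0.02 log units lower from compound 2 to compound 3 (within the scatter) shows. Compound 1 stands furthest away; the step of a number 0.31 log units lower from compound 1 to compound 3 (beyond the scatter) is beyond the scatter, though modest.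

Compound 4, `CC(C)(C)n1ncc(OCc2nnc(-c3cc(F)c(Cl)cc3Cl)o2)c(Cl)c1=O`, differs from compound 3 in one place: 2,4-dichloro-5-fluorophenyl in place of 4-bromophenyl on an aromatic carbon.

Of the measured steps, a number 0.02 log units lower from compound 2 to compound 3 (within the scatter) is the closest analogue, an exchange of one halogenated phenyl for another, and it stayed within the scatter. The step of a number 0.29 log units lower from compound 1 to compound 2 (within the scatter) swapped methoxyphenyl for a dihalogenated phenyl and also stayed within the scatter. Going by the values given here, no measured step adds a further chlorine to a phenyl that already carries halogens, so the series gives no direct guide to that. On balance a rise in this assay is expected for compound 4, of a size around a number 0.44 log units higher from compound 3 to compound 4 (beyond the scatter), with a fair chance that it falls within the scatter of compound 3.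

Compound 4 is therefore estimated at 3.65, with a range from 3.25 to 4.05.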

Compound 4, partition coefficient: 3.36
Compound 4: the middle estimate sits 0.29 log units above what was measured, and the stated range covers the measured number.
By their numbers in this assay, from the lowest: compounds 3, 2, 4 and 1 (each within the scatter of the next, the first and the last beyond it).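

In this assay, placing 2,4-dichloro-5-fluorophenyl, with 9 heavy atoms in place of the 7 of 4-bromophenyl, on the aromatic carbon of the five-membered ring gives a number 0.15 log units higher from compound 3 to compound 4 (within the scatter) and so does not separate the two groups on this read-out. Set against the other phenyl groups, the same group gives a number 0.13 log units higher from compound 2 to compound 4 (within the scatter) and a number 0.16 log units lower from compound 1 to compound 4 (within the scatter), which places compound 4, like compound 2, within the scatter of every other compound shown, even though its phenyl carries a heavier halogen pattern than any earlier one. Nothing available bears on why this exchange reads as it does.

Compound 2 and compound 4 each differ from compound 3 in more than one halogen at once, so the share of any single chlorine or fluorine in these numbers stays unresolved. Also open is how this position reads with a phenyl carrying an amine or a carboxylic acid, or with a longer alkyl chain in place of the phenyl, since every group shown here is a halogenated or methoxy-bearing phenyl.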